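A few compounds are considered here, and "the series" means these few. Any claim that something is new, unique, unknown or untested is made for them only; others in the source may bear on it.

In an ADME assay on SH-SY5Y cells (Homo sapiens) for cytotoxicity, read by MTT assay, with a stated time of 48 h (on this read-out lower numbers stand for an effect already at smaller amounts and higher numbers for an effect only at larger amounts of compound), compound 1 `O=C(NCCCCCCCn1cc(-c2ccc[n+]([O-])c2)nn1)c1ccccc1-c1ccccc1` stands at "not determined" (no result reported), so it offers no number for comparison. Compound 2 `O=C(O)c1cccc(-c2ccccc2C(=O)NCCCCCCCn2cc(-c3cccnc3)nn2)c1` gives > 500 nM in this assay, which is a limit of the assay and not a number. Compound 2 therefore has no exact position, and the only firm reference for the series is the limit of > 500 nM in this assay, at which 1 of the 2 values shown sits.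

Compound 3 `O=C(NCCCCCCCn1cc(-c2cccnc2)nn1)c1ccccc1-n1ccnn1` has not yet been measured. It differs from compound 2 by 1H-1,2,3-triazol-1-yl in place of 3-carboxyphenyl on an aromatic carbon, ortho to a large group. The 3-carboxyphenyl group therefore leaves, and the rest of the structure stays the same.

For the measured compounds named here, no measured pair shows what this exchange does, so the expectation is a judgement with wide margins. In this assay the expected change is an at least 2.5-fold lower number from compound 2 to compound 3 (0.39 log units; beyond the scatter), in the direction of lower numbers and modestly beyond the usual scatter. A result reported only as a limit also remains possible. For compound 3 the estimated value is 200 nM, with an expected range of 20 nM to 2000 nM.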

Compound 3, half-maximal effective concentration: 35.4 nM
The estimate for compound 3 lay 5.6-fold (0.75 log units) above the measured number; low and high end bracket the measured number.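

In this assay, putting 1H-1,2,3-triazol-1-yl in place of 3-carboxyphenyl, on an aromatic carbon ortho to a large group, gives an at least 14-fold lower number from compound 2 to compound 3 (1.14 log units; beyond the scatter). For the compounds shown here, compound 3 provides the first exact number, 35.4 nM, and shows that this read-out responds to an exchange at this position by more than the usual scatter, with the effect appearing at smaller amounts of compound. The comparison still rests on a single reference, which is a limit of the assay and not a number: the limit of > 500 nM in this assay, at which 1 of the 3 values shown sits.

This one step removes a carboxylic acid and a phenyl ring and adds a triazole all at once, so the compounds shown do not tell which of these parts goes with the lower number. From the compounds shown here alone, a methyl ester in place of the carboxylic acid, an amine on the same phenyl ring, or a longer chain in the otherwise shared structure remains open, as does whether the step would hold in such compounds.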